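This account rests on a few compounds, and the source may have more. Where it says the series, first, only, none or still open, it means among the compounds named here.

Measured compounds:
compound 1 `Cc1nnc(-c2ccc(-c3ccccn3)cc2)n1-c1ccccc1F` — in an assay on C6 glioma cells for displacement of a labelled ligand from sodium- and chloride-dependent glycine transporter 1 (Rattus norvegicus), read by scintillation counting, with stated times of 30 min and 10 min (on this read-out higher numbers stand for weaker inhibition and lower numbers for stronger inhibition), compound 1 gives 860 nM
compound 2 `CCc1nnc(-c2ccc(-c3ccccc3)cn2)n1-c1ccccc1F` — compound 2 gives 700 nM
compound 3 `CCc1nnc(-c2ccc(-c3ccccc3)cc2)n1-c1cccc(C)c1C` — compound 3 gives 940 nM

Compound 3 carries the highest of the three numbers, yet its gaps to compound 1 and to compound 2 both lie within the scatter, so the three read as one level in this assay rather than as an order.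

Compound 4 `CCc1nnc(-c2ccc(-c3ccccc3)cc2)n1-c1cccc(CO)c1C` differs from compound 3 in one place: hydroxy in place of hydrogen on a saturated chain carbon bound to an aromatic carbon. Among the measured compounds shown here, no pair of measured compounds shows a step of this kind, so there is nothing to calibrate it against. The expectation is a small step from compound 3 to compound 4 in this assay of a 1.2-fold higher number from compound 3 to compound 4 (0.07 log units; within the scatter), not clearly beyond the scatter, perhaps a modest move toward a higher number. For compound 4 the estimated value in this assay is 1100 nM, with a range of 400 nM to 3000 nM.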

Compound 4, half-maximal inhibitory concentration: 250 nM
Compound 4: middle estimate off by 4.4-fold (0.64 log units), on the high side; measured number below the stated range.
By their numbers in this assay, from the lowest: compound 4; then compounds 2, 1 and 3 (each within the scatter of the next).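

In this assay, among the compounds shown here, methyl to hydroxymethyl on the 2,3-dimethylphenyl group gives a 3.8-fold lower number from compound 3 to compound 4 (0.58 log units; beyond the scatter), the first step that lies beyond the scatter. So this saturated chain carbon bound to an aromatic carbon accepts a hydroxy group, and the number falls rather than rises. Nothing measured here bears on the reason for this step.

Open, going by these compounds, is whether a methoxy group, an amine, a carboxylic acid or a longer hydroxyethyl chain at this place would give a similar step. Also open, on these data alone, is whether hydroxy gives the same step on the cores of compound 1 and compound 2.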